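The source may report more compounds than this note shows. Statements on the series, on what has been measured and on what is new or still open speak of the compounds shown alone.

Measured in a functional assay on HepG2 cells (Homo sapiens) for cytotoxicity, read by MTT assay; a lower number here means a stronger inhibitor, a higher number a weaker inhibitor:
compound 1 `N#Cc1c(F)c(Cl)c2nc(N)nc(N)c2c1F`: 4.8 ug/mL
compound 2 `N#Cc1c(F)c(F)c2nc(N)nc(N)c2c1F`: 5 ug/mL
compound 3 `N#Cc1c(NCc2ccccc2)c(Cl)c2nc(N)nc(N)c2c1F`: 1.4 ug/mL

Compound 2 stands with compound 1 at the high end of these three numbers, and the two cannot be told apart: a 1.0-fold higher number from compound 1 to compound 2 (0.02 log units; within the scatter). Compound 3 gives a lower number, 1.4 ug/mL. Compound 4 `CCN(CC)c1c(C#N)c(F)c2c(N)nc(N)nc2c1F` follows from compound 2 with diethylamino in place of fluoro on an aromatic carbon, ortho to a cyano group: diethylamino in place of fluoro on an aromatic carbon. The nearest measured change is benzylamino in place of fluoro on an aromatic carbon, a 3.4-fold lower number from compound 1 to compound 3 (0.54 log units; beyond the scatter), a modest step. It was measured from compound 1, but the exchange of chloro for fluoro above lay within the scatter, so it can reasonably be carried over to compound 2. Diethylamino is a different group, and only this one amino step has been measured. A similar or somewhat smaller step towards a lower number is therefore expected in this assay. The expected step is a 2.5-fold lower number from compound 2 to compound 4 (0.40 log units; beyond the scatter). Compound 4 is estimated at 2 ug/mL, with an expected range from 0.7 ug/mL to 5.5 ug/mL.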

Compound 4, half-maximal inhibitory concentration: 1.3 ug/mL
The estimate for compound 4 lay 1.5-fold (0.19 log units) above the measured number; the measured number falls inside the stated range.
By their numbers in this assay, from the lowest: compounds 4 and 3 (each within the scatter of the next); then compounds 1 and 2 (each within the scatter of the next).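

In this assay, a second amino group on the aromatic carbon ortho to a cyano group gives a step in the same direction as the first, a 3.8-fold lower number from compound 2 to compound 4 (0.59 log units; beyond the scatter), so the change beyond the scatter no longer rests on benzylamino alone. The earlier step, a 3.4-fold lower number from compound 1 to compound 3 (0.54 log units; beyond the scatter), came from the chloro compound, whereas this one comes from compound 2, which carries fluoro in place of that chloro, and so the direction holds on both versions of the core. The compounds shown offer no measured explanation for either step.

On these data alone, what remains open is whether any amino group at this position gives the same result, or whether a plain amino group or a morpholine ring would behave differently. As far as these compounds go, it is also open whether a non-nitrogen replacement for fluoro, such as a methoxy group, would lower the number at all.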